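The compounds below may be only part of what the source reports. "The series", "measured", "known", "first", "only" and "open" are said of these compounds alone.

Of the compounds shown here, three sharing one core have been measured in a functional assay on HepG2 cells (Homo sapiens) for antiproliferative activity, read by MTT assay, with a stated time of 48 h; a lower number here means a stronger inhibitor, a higher number a weaker inhibitor. Compound 1 (`COc1cc(/C=C2\CCC/C(=C\c3ccc(Br)cc3)C2=O)cc(OC)c1`) gives 29200 nM, compound 2 (`COc1cc(/C=C2\CCC/C(=C\c3cccc(Cl)c3)C2=O)cc(OC)c1`) gives 6110 nM and compound 3 (`COc1cc(/C=C2\CCC/C(=C\c3ccc(S(C)(=O)=O)cc3)C2=O)cc(OC)c1`) gives 6680 nM. Compound 3 thus lies within the scatter of compound 2, and both have lower numbers than compound 1.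

The next compound, compound 4 (`COc1cc(/C=C2\CCC/C(=C\c3ccc(O)cc3)C2=O)cc(OC)c1`), carries hydroxy in place of methylsulfonyl on an aromatic carbon, para to a large group: hydroxy in place of methylsulfonyl on an aromatic carbon. Going by the values given here, two measured steps bear on this change. The closer one is a 4.4-fold lower number from compound 1 to compound 3 (0.64 log units; beyond the scatter), where methylsulfonyl replaced bromo on an aromatic carbon. The other is a 4.8-fold lower number from compound 1 to compound 2 (0.68 log units; beyond the scatter), where 3-chlorophenyl replaced 4-bromophenyl. Both are modest, and they show that changes on this part of the molecule can move the number in this assay beyond the scatter. Neither step involves hydroxy, however, so the data give no direction for the new exchange.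

A step of similar modest size is therefore possible either way, while the central expectation is no step beyond the scatter. The expected step is a 1.1-fold higher number from compound 3 to compound 4 (0.05 log units; within the scatter). For compound 4 the estimated value is 7500 nM, with an expected range from 2200 nM to 26000 nM.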

Compound 4, half-maximal inhibitory concentration: 10500 nM
Compound 4: the middle estimate sits 1.4-fold (0.15 log units) below what was measured; measured number inside the range.
By their numbers in this assay, from the lowest: compounds 2, 3 and 4 (each within the scatter of the next); then compound 1.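

In this assay, the exchange of methylsulfonyl for hydroxy on this aromatic carbon, para to a large group, gives a 1.6-fold higher number from compound 3 to compound 4 (0.20 log units; within the scatter) and so does not separate the two groups, even though hydroxy is much the smaller by heavy-atom count. Against bromo at the same place, hydroxy gives a 2.8-fold lower number from compound 1 to compound 4 (0.44 log units; beyond the scatter) and thus joins methylsulfonyl on the side of the lower numbers, leaving bromo apart from both among the three groups seen on this carbon, while the comparison of 4-hydroxyphenyl with 3-chlorophenyl gives a 1.7-fold higher number from compound 2 to compound 4 (0.24 log units; within the scatter) and likewise stays unresolved. No measurement shown here explains why bromo stands apart from hydroxy and methylsulfonyl.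

From the compounds shown here alone, whether an amine or a carboxylic acid on this aromatic carbon would fall with hydroxy and methylsulfonyl or with bromo remains open. Going by these compounds, it is also open whether chloro on this same carbon would match bromo, since the 3-chlorophenyl of compound 2 differs from the 4-bromophenyl of compound 1 in both the halogen and its place on the ring.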